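This account rests on a few compounds, and the source may have more. Where it says the series, first, only, none or still open, it means among the compounds named here.

The study centres on a set of compounds sharing one core. Among the measured compounds shown here, compound 1, `COc1ccccc1-n1cc(COc2ccc3c(c2)CCC3)nn1`, is the only member with a number attached: in an ADME assay on HEK293 cells (Homo sapiens) for inhibition, read by MTT assay, with a stated time of 48 h, tested at 25 uM (a higher number here means more inhibition at the concentration tested (going by the name of the read-out), a lower number less inhibition), compound 1 gives 19.8%. Two further entries carry no number at all. For compound 2, `COc1ccc(NC(=O)Cn2cc(COc3ccc4c(c3)CCC4)nn2)cc1`, the result in this assay is "not determined" (no result reported), and for compound 3, `O=C(Cn1cc(COc2ccc3c(c2)CCC3)nn1)Nc1cccc([N+](=O)[O-])c1`, the result in this assay is likewise "not determined" (no result reported). Compound 1 therefore stands alone as the single reference point, with nothing above or below it to compare against.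

The compound still to be measured is compound 4, `Brc1ccccc1-n1cc(COc2ccc3c(c2)CCC3)nn1`. It differs from compound 1 in one place: bromo in place of methoxy on an aromatic carbon. For the measured compounds named here, no step between two measured compounds exists here, so the size and direction of this change can only be judged from compound 1 itself. With nothing else to go on, the expectation is that the step from compound 1 to compound 4 in this assay stays within or only just beyond the usual scatter, and if anything leans upward, as a number 6.2 percentage points higher from compound 1 to compound 4 (within the scatter). On that basis compound 4 is estimated to give 26% in this assay, with a range from 10% to 42%.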

Compound 4, a percentage reported as inhibition, at one concentration (the size of the read-out at that concentration, not a potency): 16.5%
Compound 4: middle estimate off by 9.5 percentage points, on the high side, within the range that was stated.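

Bromo in place of methoxy gives the first readable step at this place, an aromatic carbon ortho to a large group: in this assay the change amounts to a number 3.3 percentage points lower from compound 1 to compound 4 (within the scatter) and so cannot be told apart from repeat variation. The swap removes the oxygen, the methoxy's one hydrogen-bond acceptor, and replaces two heavy atoms with one, yet this exchange leaves no readable mark on the number, so the methoxy group is not shown to matter for this read-out at this place. No independent measurement bears on the result, so the step stands as an observation without an explanation.

On these data alone, with a single step at one place, no trend can be drawn from compound 1 and compound 4 alone, and it remains open whether any group at this place would move the number beyond the scatter. An amine, a carboxylic acid or a longer chain such as ethoxy in the same place could test this, and whether the exchange of methoxy for bromo would behave the same way elsewhere on the aromatic ring also stays unanswered.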